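The source may hold more compounds than are shown below. What is called first, only, known or untested is meant among the compounds shown, and "the series" means these compounds.

Measured compounds:
Compound 1, `COc1ccc(C(=O)/C=C/c2cc(-c3cc(OC)c(OC)c(OC)c3)n3nc(-c4ccccc4)cc3n2)cc1` — 79800 nM
Compound 2, `COc1cc(-c2cc(C(=O)/C=C/c3ccccc3)nc3cc(-c4ccccc4)nn23)cc(OC)c1OC` — 44800 nM

Both compounds were tested in an ADME assay on HEK293 cells (Homo sapiens) for antiproliferative activity, read by MTT assay, with a stated time of 24 h; on this read-out lower numbers stand for stronger inhibition and higher numbers for weaker inhibition. Going by the values given here, compound 2 gives the lower of the two numbers, but the single measured step, a 1.8-fold lower number from compound 1 to compound 2 (0.25 log units; within the scatter), leaves the two values within the scatter of each other, so the two cannot be told apart.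

Compound 3, `COc1cc(-c2cc(/C=C/C(=O)c3ccccc3)nc3cc(-c4ccccc4)nn23)cc(OC)c1OC`, has not yet been measured. It differs from compound 2 in one place: 2-benzoylethenyl in place of (2-phenylethenyl)carbonyl on an aromatic carbon. The two compounds are built from the same atoms, joined differently.

Among the compounds with values here, the only measured step, from compound 1 to compound 2, swapped one aryl group for another on the same framework and did not probe this rearrangement, so it offers no direct guide. Lacking any measured step that bears on it, no shift beyond the scatter is expected; the estimated step is a 1.0-fold higher number from compound 2 to compound 3 (0.00 log units; within the scatter). Compound 3 is therefore expected to give about 45000 nM, within a range from 15000 nM to 135000 nM.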

Compound 3, half-maximal inhibitory concentration: >= 100000 nM
Compound 3 was reported as a limit; the forecaster's own chance of this, stated with the estimate: 10%; at least 2.2-fold (0.34 log units) between middle value and limit.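

Turning the chain around on this aromatic carbon, so that the ethenyl end rather than the carbonyl end is attached to the core, gives an at least 2.2-fold higher number from compound 2 to compound 3 (0.34 log units; beyond the scatter) in this assay, an at least modest step and the first here that lies beyond the scatter, even though the two groups are built from the same atoms. As far as these compounds go, the result for compound 3 is a limit and not a number, so the full size of this step stays unknown: the limit of >= 100000 nM in this assay, at which 1 of the 3 values shown sits. The step with hydrogen in place of methoxy on an aromatic carbon, an at least 1.2-fold higher number from compound 1 to compound 3 (0.09 log units; that floor lies within the scatter), cannot be read, as its floor lies within the scatter.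

From the compounds shown here alone, whether an amine or a carboxylic acid on the benzoyl ring of compound 3 would change its result stays open. So does the effect of a longer chain in place of 2-benzoylethenyl on this carbon.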